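Changing the Aryl Group on the Sulfur

The source may report more compounds than this note shows. Statements on the series, on what has been measured and on what is new or still open speak of the compounds shown alone.

Compound 1 `CC(O)(C[S+]([O-])c1ccc(F)cc1F)C(=O)Nc1ccc([N+](=O)[O-])cc1C(F)(F)F` gives in a functional assay on VCaP cells (Homo sapiens) for antiproliferative activity (on this read-out higher numbers stand for weaker inhibition and lower numbers for stronger inhibition), a limit of > 100000 nM.
Compound 2 `CC(O)(C[S+]([O-])c1ccc(F)c(F)c1)C(=O)Nc1ccc([N+](=O)[O-])cc1C(F)(F)F` gives in this assay limits of > 100000 nM; > 100000 nM (2 entries).
Compound 3 `CC(O)(C[S+]([O-])c1ccc(C(F)(F)F)cc1)C(=O)Nc1ccc([N+](=O)[O-])cc1C(F)(F)F` gives in this assay 24200 nM.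

Among the compounds with values here, compound 3 holds the only actual number among the three; the other two entries are limits, one of them being (the limit of > 100000 nM in this assay, at which 1 of the 3 values shown sits). Within the data shown here, the one measured step, an at least 4.1-fold lower number from compound 1 to compound 3 (0.61 log units; beyond the scatter), shows that the aryl group on the sulfur can shift the read-out at least modestly. Compound 4 `CC(O)(C[S+]([O-])c1ccccc1OC(F)(F)F)C(=O)Nc1ccc([N+](=O)[O-])cc1C(F)(F)F` differs from compound 3 by 2-(trifluoromethoxy)phenyl in place of 4-(trifluoromethyl)phenyl on a sulfur. Among the measured compounds shown here, no measured step compares a 2-substituted aryl with a 4-substituted one, so the direction is open. The estimate for compound 4 is a step of a 2.1-fold higher number from compound 3 to compound 4 (0.32 log units; beyond the scatter), expected to be modest and toward weaker inhibition. Compound 4 is estimated at 50000 nM, with a range from 15000 nM to 150000 nM.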

Compound 4, half-maximal inhibitory concentration: 20700 nM
Estimate against measurement, compound 4: 2.4-fold (0.38 log units) above; the range from low to high includes it.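

The 2-(trifluoromethoxy)phenyl group on the sulfur matches the 4-(trifluoromethyl)phenyl group in this assay with a 1.2-fold lower number from compound 3 to compound 4 (0.07 log units; within the scatter) so a measurable number at this position is not tied to a single substituent or ring position. Compared with the 2,4-difluorophenyl group, the new group gives an at least 4.8-fold lower number from compound 1 to compound 4 (0.68 log units; beyond the scatter) and this repeats the direction seen with compound 3. Compound 1 itself remains a limit: the limit of > 100000 nM in this assay, at which 1 of the 4 values shown sits.

Open, on these data alone, is how an unsubstituted phenyl or an aryl carrying an amine would compare. Also open, as far as these compounds go, is what a sulfone or sulfide in place of the sulfoxide would do on the same core.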